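Piperidine nitrogen substituent growth in the sulfonyl series

The source may report more compounds than this note shows. Statements on the series, on what has been measured and on what is new or still open speak of the compounds shown alone.

Three members of the series have numbers in a functional assay on HeLa cells for agonist activity at 5-hydroxytryptamine receptor 6 (Homo sapiens), read by cAMP accumulation and immunoassay; on this read-out lower numbers stand for an effect already at smaller amounts and higher numbers for an effect only at larger amounts of compound. Compound 1 `CN1CCC(n2cc(S(=O)(=O)c3cccc(F)c3)c3cccnc32)C1` gives 231 nM. Compound 2 `O=S(=O)(c1cccc(F)c1)c1cn(C2CCCNC2)c2ncccc12` gives 67 nM. Compound 3 `CCN1CCCC(n2cc(S(=O)(=O)c3cccc(F)c3)c3cccnc32)C1` gives 60 nM, the smallest number shown, yet the step of a 1.1-fold lower number from compound 2 to compound 3 (0.05 log units; within the scatter) lies within the scatter, so compound 3 is set apart only from compound 1, by a 3.9-fold lower number from compound 1 to compound 3 (0.59 log units; beyond the scatter). The two steps that exchange the whole ring on the aromatic nitrogen, a 3.4-fold lower number from compound 1 to compound 2 (0.54 log units; beyond the scatter) and a 3.9-fold lower number from compound 1 to compound 3 (0.59 log units; beyond the scatter), are the only ones beyond the scatter; the step that touches only the substituent on the amine nitrogen in the ring, a 1.1-fold lower number from compound 2 to compound 3 (0.05 log units; within the scatter), is not.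

Compound 4 `CC(C)N1CCCC(n2cc(S(=O)(=O)c3cccc(F)c3)c3cccnc32)C1` carries methyl in place of hydrogen on a saturated chain carbon bound to an amine nitrogen in a ring and a saturated chain carbon. For the measured compounds named here, the one measured step that bears on this change is a 1.1-fold lower number from compound 2 to compound 3 (0.05 log units; within the scatter), which grew the same substituent from hydrogen to ethyl and stayed within the scatter. Going by the values given here, nothing among the measured compounds points to a move in either direction for a further methyl on that substituent, so no step beyond the scatter is expected in this assay, the change being estimated as a 1.1-fold lower number from compound 3 to compound 4 (0.04 log units; within the scatter). Compound 4 is therefore expected at 55 nM in this assay, with a range from 25 nM to 130 nM.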

Compound 4, half-maximal effective concentration: 172 nM
The estimate for compound 4 lay 3.1-fold (0.50 log units) below the measured number, outside the stated range (above it).
By their numbers in this assay, from the lowest: compounds 3 and 2 (each within the scatter of the next); then compounds 4 and 1 (each within the scatter of the next).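

The substituent on the amine nitrogen in the ring is not indifferent in this assay: ethyl could not be told from hydrogen, but the added methyl on the saturated chain carbon bound to that nitrogen gives a step beyond the scatter (a 2.9-fold higher number from compound 3 to compound 4 (0.46 log units; beyond the scatter)), and the change from hydrogen to isopropyl gives another (a 2.6-fold higher number from compound 2 to compound 4 (0.41 log units; beyond the scatter)). The tolerance seen for ethyl therefore does not extend to isopropyl, so one compound with a larger group on this nitrogen was needed to show a limit at this position. The advantage of the piperidine compounds over compound 1 is also absent here, since the exchange to 1-isopropylpiperidin-3-yl stays within the scatter (a 1.3-fold lower number from compound 1 to compound 4 (0.13 log units; within the scatter)). No measurement at hand offers an explanation for this turn.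

Whether the branch at that carbon or the added carbon itself accounts for the step stays open, and a propyl chain on the amine nitrogen in the ring would separate the two. Also open, on these data alone, is how 1-methylpiperidin-3-yl would stand, as it would show how far compound 1 reflects its ring and how far its methyl.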